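Moving a halogen on the aryl ring of a dihydropyridine core

This account rests on a few compounds, and the source may have more. Where it says the series, first, only, none or still open, it means among the compounds named here.

Compound 1 `COC(=O)C1=C(C)N=C(C)/C(=C(\O)OC)C1c1cc([N+](=O)[O-])ccc1O`: in a functional assay (muscle tissue) with Cavia porcellus as the target (on this read-out lower numbers stand for an effect already at smaller amounts and higher numbers for an effect only at larger amounts of compound), compound 1 gives 100 nM.
Compound 2 `COC(=O)C1=C(C)N=C(C)/C(=C(\O)OC)C1c1cccc([N+](C)(C)C)c1`: in this assay compound 2 gives 50100 nM.
Compound 3 `COC(=O)C1=C(C)N=C(C)/C(=C(\O)OC)C1c1ccccc1I`: in this assay compound 3 gives 46.8 nM.

Of the compounds shown here, three sharing one core have been measured. Compound 3 shows the lowest of the three numbers. Its gap to compound 1 is small but still beyond the usual scatter, while compound 2 lies far above both.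

The next compound, compound 4 `COC(=O)C1=C(C)N=C(C)/C(=C(\O)OC)C1c1ccc(F)cc1`, differs from compound 3 in one place: 4-fluorophenyl in place of 2-iodophenyl on a saturated ring carbon. Going by the values given here, no measured pair in this set shows a change of this kind, so nothing here gives the size of the step directly.

The expectation is that compound 4 in this assay will move toward a higher number than compound 3, by a step of roughly a 21-fold higher number from compound 3 to compound 4 (1.33 log units; beyond the scatter), beyond the scatter. Compound 4 is therefore estimated at 1000 nM, with a plausible range from 200 nM to 5000 nM.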

Compound 4, half-maximal effective concentration: 129 nM
For compound 4 the middle estimate is 7.8-fold (0.89 log units) above the measured one; measured number below the stated range.
By their numbers in this assay, from the lowest: compound 3; then compounds 1 and 4 (each within the scatter of the next); then compound 2.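

In this assay, putting 4-fluorophenyl in place of 2-iodophenyl on the saturated ring carbon gives a 2.8-fold higher number from compound 3 to compound 4 (0.44 log units; beyond the scatter) and so counts as a modest step. This position therefore accepts a different halogen at a different place on the aryl ring without a large shift in the number, even though the two groups have the same count of heavy atoms and differ in nothing else that is counted here. Nothing available explains the size of this step. Since the halogen and its place on the ring change together, this single pair cannot show how much of the step belongs to each. Also open, on these data alone, is how this position would respond to an unsubstituted phenyl ring or to an aryl ring carrying an amine or a carboxylic acid.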